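Notes on a cyclohexylamine variation in a kinase inhibitor set

A few compounds are considered here, and "the series" means these few. Any claim that something is new, unique, unknown or untested is made for them only; others in the source may bear on it.

Measured so far:
compound 1, `CO[C@H]1CC[C@H](Nc2cc(NCc3cnccc3C(F)(F)F)ncc2C#N)CC1`: > 10000 nM
compound 2, `N#Cc1cnc(NCc2ccccc2C(F)(F)F)cc1N[C@H]1C[C@H](C(N)=O)C1`: > 10000 nM
compound 3, `N#Cc1cnc(NCc2cncnc2OCC(F)F)cc1N[C@H]1CC[C@@H](O)CC1`: 90 nM

In an assay on isolated protein for inhibition of protein kinase C delta type (Homo sapiens), read by TR-FRET, with a stated time of 2 h (on this read-out lower numbers stand for stronger inhibition and higher numbers for weaker inhibition), compound 1 gives only a limit, > 10000 nM. Compound 2 likewise gives only a limit, > 10000 nM. Compound 3 gives a measured number, 90 nM. Compound 1 thus sits at the limit of > 10000 nM in this assay, at which 2 of the 3 values shown sit, with compound 2 beside it, while compound 3 stands apart with a real value. Compound 4, `CC1(C)C[C@H](Nc2cc(NCc3cnccc3C(F)(F)F)ncc2C#N)CC[C@H]1O`, carries 4-hydroxy-3,3-dimethylcyclohexyl in place of 4-methoxycyclohexyl on a nitrogen on an aromatic ring. For the measured compounds named here, no measured pair differs in one place, so the size of this step is unknown; a move toward lower numbers in this assay of modest size is expected, though a further limit remains possible. For compound 4 a value of 4000 nM is estimated, ranging from 300 nM to 30000 nM. The expected step is an at least 2.5-fold lower number from compound 1 to compound 4 (0.39 log units; beyond the scatter).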

Compound 4, half-maximal inhibitory concentration: 2200 nM
Beside the measured number, compound 4's estimate is 1.8-fold (0.26 log units) above it; low and high end bracket the measured number.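

In this assay, 4-hydroxy-3,3-dimethylcyclohexyl in place of 4-methoxycyclohexyl on a nitrogen on an aromatic ring gives an at least 4.5-fold lower number from compound 1 to compound 4 (0.65 log units; beyond the scatter). For the compounds shown here, this is the first readable step, and it shows that a change at this position alone, on the core of compound 1, can produce a measurable value. Compound 1 sits at a limit, so the full size of the step stays open: the limit of > 10000 nM in this assay, at which 2 of the 4 values shown sit.

The change replaces the methoxy group with a hydroxy group and adds two methyl groups at once, and the compounds shown do not separate these two changes. Going by these compounds, whether 4-methoxy-3,3-dimethylcyclohexyl or 4-aminocyclohexyl on this nitrogen would give a similar value remains open.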